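The source may hold more compounds than are shown below. What is called first, only, known or untested is meant among the compounds shown, and "the series" means these compounds.

In a functional assay on A549 cells (Homo sapiens) for antiproliferative activity, read by sulforhodamine B assay, with a stated time of 72 h (a higher number here means a weaker inhibitor, a lower number a stronger inhibitor), three compounds set the background, and only one of them gives a number. Compound 1 `Cn1cc(/C=C2\CCC=CC2=O)c2ccccc21` gives 4920 nM. Compound 2 `O=C1C=CCC/C1=C\c1ccccc1OC(F)(F)F` has no result, and its entry reads "not determined" (no result reported). Compound 3 `COc1cc(/C=C2\CNC=CC2=O)cc(OC)c1OC` gives > 25000 nM, which is a limit of the assay and not a number. Going by these compounds, compound 3 therefore stands at the limit of > 25000 nM in this assay, at which 1 of the 3 values shown sits, and its true potency remains unknown.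

The next compound, compound 4 `COc1cc(/C=C2\CN(S(=O)(=O)c3ccccc3)C=CC2=O)cc(OC)c1OC`, keeps the core of compound 3 and changes it in one place: phenylsulfonyl in place of hydrogen on an amine nitrogen in a ring. This puts phenylsulfonyl in place of hydrogen on an amine nitrogen in a ring. For the measured compounds named here, no pair of measured compounds differs in one place, so no measured step guides the expectation. Going by the values given here, the only number for comparison is that of compound 1 at 4920 nM, and this suggests that a measurable value is attainable in this assay. A sizeable move toward stronger inhibition is therefore expected, though with wide uncertainty. The expected change, an at least 8.3-fold lower number from compound 3 to compound 4 (0.92 log units; beyond the scatter), is an estimate measured from a limit rather than from a number. For compound 4 the estimated value is 3000 nM, with an expected range from 400 nM to 20000 nM.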

Compound 4, half-maximal inhibitory concentration: 22400 nM
Compound 4: the middle estimate sits 7.5-fold (0.87 log units) below what was measured, and the stated range ends below it.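

In this assay, for the compounds shown here, compound 4 gives 22400 nM, the first single number on the core it shares with compound 3, so this amine nitrogen in a ring can carry a group as large as phenylsulfonyl and still yield a readable value. The change gives an at least 1.1-fold lower number from compound 3 to compound 4 (0.04 log units; that floor lies within the scatter), which fixes only the smallest possible size of the step; the true step may be larger, but the printed floor alone does not establish a gain in potency. Compound 3 stands at a limit of the assay and not at a number, and this is why the step has only a floor: the limit of > 25000 nM in this assay, at which 1 of the 4 values shown sits.

The compounds shown leave open how a smaller group on the same nitrogen, such as methylsulfonyl or acetyl, would read in this assay, and so whether the sulfonyl link or the phenyl ring matters for the value of compound 4. They also leave open whether a chlorine or a methoxy group on that phenyl ring would move the number in either direction.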